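Methyl Ester to Free Acid in Two Related Series

This account rests on a few compounds, and the source may have more. Where it says the series, first, only, none or still open, it means among the compounds named here.

Compound 1, `COC(=O)c1ccc2ccc(C(=O)c3ccccc3)c-2cc1`, gives 28.9%.
Compound 2, `O=C(O)c1ccc2ccc(C(=O)c3ccccc3)c-2cc1`, gives 32.9%.
Compound 3, `COC(=O)Cc1ccc2ccc(C(=O)c3ccc(C(F)(F)F)cc3)c-2cc1`, gives 1%.

These values come from an assay on cells for displacement of a labelled ligand from Orexin receptor type 2 (Homo sapiens), read by scintillation counting, with stated times of 10 min and 90 min, tested at 10 uM; on this read-out higher numbers stand for more inhibition at the one concentration tested (going by the name of the read-out) and lower numbers for less inhibition. Compound 1 and compound 2 share one core and differ only by hydrogen in place of methyl on an oxygen next to a carbonyl group. That change produced a number 4 percentage points higher from compound 1 to compound 2 (within the scatter), so the two values are not distinguishable from each other.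

Compound 3 carries a different core, and the difference between the two cores is not broken down here. In this assay compound 3 gives 1%, the lowest of the three numbers and beyond the scatter from both compound 1 and compound 2.

Compound 4, `O=C(O)Cc1ccc2ccc(C(=O)c3ccc(C(F)(F)F)cc3)c-2cc1`, has not been measured. It differs from compound 3 by hydrogen in place of methyl on an oxygen next to a carbonyl group. Going by the values given here, this is the same change as the one from compound 1 to compound 2, made at the same kind of place.

Among the compounds with values here, the step from compound 3 to compound 4 is expected to be small, a number 4 percentage points higher from compound 3 to compound 4 (within the scatter), because a number 4 percentage points higher from compound 1 to compound 2 (within the scatter) is the only measured example of this change and stayed within the scatter. Since compound 3 starts near the bottom of the read-out, compound 4 is estimated at 5%, with a range from -5% to 20%. On these data alone, this rests on a single comparison, so the outcome remains open.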

Compound 4, a percentage reported as inhibition, at one concentration (the size of the read-out at that concentration, not a potency): 11.2%
For compound 4 the middle estimate is 6.2 percentage points below the measured one; measured number inside the range.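

In this assay, putting hydrogen in place of methyl on an oxygen next to a carbonyl group gives a number 10.2 percentage points higher from compound 3 to compound 4 (beyond the scatter). Set beside the earlier example, the change shows no measurable difference between the two cores, which means that on this small evidence its effect carries over from one core to the other: the same change on two cores in this assay, a number 4 percentage points higher (within the scatter) from compound 1 to compound 2 and a number 10.2 percentage points higher (beyond the scatter) from compound 3 to compound 4, 6.2 percentage points apart, within the scatter of two such steps. Going by these compounds alone, this does not establish a rule for the series, since it rests on only two pairs of compounds, one step within the scatter and the other beyond it, and a percentage at a single concentration is not a potency, leaving open how far binding strength moves with this change.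

The compounds shown do not separate the effect of the trifluoromethyl group from that of the extra carbon in the carboxymethyl chain, as the two cores differ in both. They also leave open how the series would respond if the carboxylic acid gave way to an amide or an amine, or if a longer chain joined the acid to the core.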